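Replacing a Chloropropyl Chain with a Cyclopropyl Urea

This account rests on a few compounds, and the source may have more. Where it says the series, first, only, none or still open, it means among the compounds named here.

Compound 1 `O=C(CCCl)Nc1ccc(S(=O)(=O)Oc2ccccc2I)cc1` was tested in a functional assay on MCF7 cells (Homo sapiens) for antiproliferative activity, read by sulforhodamine B assay, with a stated time of 48 h (a higher number here means a weaker inhibitor, a lower number a stronger inhibitor), where compound 1 gives 8900 nM. Compound 2 `O=C(CCCCl)Nc1ccc(S(=O)(=O)Oc2ccccc2I)cc1` carries one more carbon in its chain, and in this assay compound 2 gives 6300 nM. For the measured compounds named here, the single measured step, a 1.4-fold lower number from compound 1 to compound 2 (0.15 log units; within the scatter), is too small to count as a real difference. Compound 2 therefore holds the lowest of the two numbers shown, yet it sits within the scatter of compound 1, so neither can be called the stronger inhibitor.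

Compound 3 `O=C(Nc1ccc(S(=O)(=O)Oc2ccccc2I)cc1)NC1CC1` changes the same position more deeply: cyclopropylamino in place of 3-chloropropyl on a carbonyl carbon. Going by the values given here, only the step from compound 1 to compound 2 bears on this change, and it altered just the chain length, without any effect beyond the scatter. Among the compounds with values here, no measured pair exchanges the chlorinated chain for a ring-bearing amino group, so the data give no direction for compound 3. The expected outcome for compound 3 is therefore a step of no change at the digits printed from compound 2 to compound 3 (within the scatter), none beyond the scatter. Compound 3 is expected to give about 6300 nM, within a range from 2000 nM to 20000 nM.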

Compound 3, half-maximal inhibitory concentration: 7400 nM
Estimate against measurement, compound 3: 1.2-fold (0.07 log units) below; measured number inside the range.
By their numbers in this assay, from the lowest: compounds 2, 3 and 1 (each within the scatter of the next).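

In this assay, cyclopropylamino on the carbonyl carbon gives a 1.2-fold higher number from compound 2 to compound 3 (0.07 log units; within the scatter) and a 1.2-fold lower number from compound 1 to compound 3 (0.08 log units; within the scatter), so neither step separates compound 3 from the chlorinated compounds. This shows that the position tolerates much more than a change in chain length: the chlorine and the open chain leave, while a three-membered carbon ring and a hydrogen-bond donor enter, and the result stays within the scatter, so among these three compounds the chlorine is not needed to keep the number at this level. No measurement here explains why the number holds across this exchange.

Going by these compounds, what remains open is which part of the new group, if any, matters, since the ring and the added nitrogen enter together; a straight propylamino chain would test the ring with the nitrogen kept, and a cyclopropyl group bonded directly to the carbonyl carbon would test the nitrogen with the ring kept. On these data alone, it is also open whether any group here can move the number beyond the scatter, for example a phenylamino group or a carboxylic acid at the end of a longer chain.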